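This account rests on a few compounds, and the source may have more. Where it says the series, first, only, none or still open, it means among the compounds named here.

Of the compounds shown here, three have been measured in a functional assay on SNB-19 cells (Homo sapiens) for inhibition, read by MTT assay, with a stated time of 7 days; a lower number here means a stronger inhibitor of growth, a higher number a weaker inhibitor of growth. Compound 1 `Cc1noc(Cn2nnc3c(C(N)=O)ncn3c2=O)n1` reads > 50000 nM, which is a limit of the assay and not a number. Compound 2 `C#CC/N=N/Nc1[nH]cnc1C(N)=O` gives 39100 nM. Compound 3 `NC(=O)c1nc[nH]c1N/N=N/Cc1ccco1` reads > 50000 nM, again a limit. Compound 3 thus sits at the limit of > 50000 nM in this assay, at which 2 of the 3 values shown sit.

Compound 4 `NC(=O)c1nc[nH]c1N/N=N/Cc1ccsc1` has thiophen-3-yl in place of furan-2-yl on a saturated chain carbon bound to a double-bonded nitrogen. Going by the values given here, only one measured step bears on this place: an at least 1.2-fold higher number from compound 2 to compound 3 (0.10 log units; that floor lies within the scatter), where furan-2-yl replaced ethynyl. Among the compounds with values here, no measured step shows a change at this carbon beyond the scatter, so no step beyond the scatter is expected in this assay, in either direction. The limit does leave the true standing of compound 3 open.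

For compound 4 the expected value is 45000 nM, with an estimated range of 22000 nM to 80000 nM. The estimate corresponds to an at least 1.1-fold lower number from compound 3 to compound 4 (0.04 log units; that floor lies within the scatter).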

Compound 4, concentration for 50% growth inhibition: > 50000 nM
Compound 4: only a limit was reported (the forecaster's own chance of this, stated with the estimate: 60%); middle value at least 1.1-fold (0.04 log units) away from the limit.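

Compound 4 gives only a limit in this assay, so thiophen-3-yl joins furan-2-yl as a second five-membered aromatic ring on this saturated chain carbon that reaches it: the limit of > 50000 nM in this assay, at which 3 of the 4 values shown sit. Compound 3 and compound 4 both carry limits, and the step between them cannot be read, so the exchange of the oxygen-containing ring for the sulfur-containing one has no measurable size here. Against ethynyl, thiophen-3-yl gives an at least 1.2-fold higher number from compound 2 to compound 4 (0.10 log units; that floor lies within the scatter), so a step beyond the scatter at this carbon is still not shown, now for either ring.

The limits leave open how weak compound 3 and compound 4 truly are, and whether the two rings differ at all. Also open, going by these compounds, is whether an amine, a carboxylic acid or a longer chain on this carbon would give a value that can be read.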